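Adding a Second Methyl to Compound 2's Aryl Ring

The source may report more compounds than this note shows. Statements on the series, on what has been measured and on what is new or still open speak of the compounds shown alone.

Compound 2 `Cc1ccc(-c2nc(CN3CCC(C(=O)NCCCN4C[C@H](C)C[C@H](C)C4)CC3)c(C)o2)cc1` was tested in a physicochemical assay for solubility, in phosphate buffer, measured as kinetic solubility, at pH 7.4; a lower number here means a less soluble compound, a higher number a more soluble compound. In this assay compound 2 gives > 69 ug/mL, which is a limit of the measurement rather than a number. The change to compound 3 `Cc1ccc(-c2nc(CN3CCC(C(=O)NCCCN4C[C@H](C)C[C@H](C)C4)CC3)c(C)o2)c(C)c1` is methyl in place of hydrogen on an aromatic carbon. For the measured compounds named here, one measured step touches the same ring: the step from compound 1 `Cc1oc(-c2ccc(Cl)cc2)nc1CN1CCC(C(=O)NCCCN2C[C@H](C)C[C@H](C)C2)CC1` to compound 2, a step that the two limits leave unreadable from compound 1 to compound 2. In this assay compound 1 gives > 72 ug/mL, again a limit. Because both the limit of > 69 ug/mL in this assay, at which 1 of the 2 values shown sits, and the limit of > 72 ug/mL in this assay, at which 1 of the 2 values shown sits, are limits, the size of that step cannot be read, and it carries no lesson for the methyl added in compound 3. The step from compound 2 to compound 3 is therefore expected to be an at least 1.1-fold lower number from compound 2 to compound 3 (0.06 log units; that floor lies within the scatter), with no direction that the data can support. Compound 3 is estimated at 60 ug/mL in this assay, within the range 20 ug/mL to 100 ug/mL.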

Compound 3, solubility: > 71 ug/mL
Compound 3: a limit, no number (the forecaster's own chance of this, stated with the estimate: 55%); middle value at least 1.1-fold (0.07 log units) from the limit.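

In this assay, for the compounds shown here, compound 1, compound 2 and compound 3 each give a limit and not a number, and no step among them can be read. The compounds shown leave open where each true value lies, and whether the methyl added in compound 3 shifts it.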